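Amidine series: nitrogen substituent exchange toward compound 4

The source may report more compounds than this note shows. Statements on the series, on what has been measured and on what is new or still open speak of the compounds shown alone.

Three compounds share one core and differ only in the group on the nitrogen on the aromatic ring. Compound 1 `CCCCN(C1=NCCN1)c1c(Br)cccc1Br` gives 11 in a physicochemical assay for acid dissociation. Compound 2 `CC(C)N(C1=NCCN1)c1c(Br)cccc1Br` gives 11.2 in this assay, and compound 3 `C/C=C/CN(C1=NCCN1)c1c(Br)cccc1Br` gives 11. Compound 2 sits with the other two: the step of a number 0.20 log units higher from compound 1 to compound 2 (within the scatter) and the step of a number 0.20 log units lower from compound 2 to compound 3 (within the scatter) both fall within the scatter, as does the step of no change at the digits printed from compound 1 to compound 3 (within the scatter). On these numbers the three substituents at that nitrogen are not told apart.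

Compound 4 `Brc1cccc(Br)c1N(Cc1ccco1)C1=NCCN1` has not yet been measured. Relative to compound 2 the change is (furan-2-yl)methyl in place of isopropyl on a nitrogen on an aromatic ring. The measured steps that bear on it are the two that exchange groups at the same nitrogen, a number 0.20 log units higher from compound 1 to compound 2 (within the scatter) and a number 0.20 log units lower from compound 2 to compound 3 (within the scatter), both within the scatter. Within the data shown here, no measured compound carries a ring or an acceptor in that group, so the data say nothing specific about the (furan-2-yl)methyl group itself. The expected step is therefore a number 0.30 log units lower from compound 2 to compound 4 (within the scatter), which is no change beyond the scatter. Compound 4 is estimated at 10.9, with a range from 10.4 to 11.4.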

Compound 4, acid dissociation constant: 10.5
Estimate against measurement, compound 4: 0.40 log units above; the measured number falls inside the stated range.
By their numbers in this assay, from the lowest: compound 4; then compounds 1, 3 and 2 (each within the scatter of the next).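

In this assay, among these compounds, this nitrogen on an aromatic ring no longer looks indifferent to its substituent: (furan-2-yl)methyl in place of isopropyl gives a number 0.70 log units lower from compound 2 to compound 4 (beyond the scatter), the first exchange here to pass the scatter. The same direction appears against the other two groups, with a number 0.50 log units lower from compound 1 to compound 4 (beyond the scatter) and a number 0.50 log units lower from compound 3 to compound 4 (beyond the scatter), so compound 4 stands apart from all three earlier compounds, whereas those three could not be told apart. The entering group differs from the three it is compared with by carrying a five-membered aromatic ring with a hetero atom and a hydrogen-bond acceptor, and no measurement here accounts for the lower number.

The compounds shown leave open whether the lower number goes with the ring or with the oxygen: a benzyl group would offer a ring without oxygen, and a 2-methoxyethyl group an oxygen without a ring. Also open, from the compounds shown here alone, is whether the step persists with a longer chain on that nitrogen, as in a (furan-2-yl)ethyl group.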